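This account rests on a few compounds, and the source may have more. Where it says the series, first, only, none or still open, it means among the compounds named here.

Measured compounds:
- compound 1 `CN1CCN(c2ccc(Nc3nc(-c4cccc(NC(=O)c5ccc(F)cc5)c4)sc3C(N)=O)cc2)CC1`: 2820 nM
- compound 2 `CN1CCN(c2ccc(Nc3nc(-c4cccc(NC(=O)c5ccccc5)c4)sc3C(N)=O)cc2)CC1`: 6360 nM
- compound 3 `CN1CCN(c2ccc(Nc3nc(-c4cccc(NC(=O)c5ccc(Cl)cc5)c4)sc3C(N)=O)cc2)CC1`: 5700 nM

In a functional assay on Raji cells (Homo sapiens) for antiproliferative activity, read by CCK-8 assay, with a stated time of 72 h (on this read-out higher numbers stand for weaker inhibition and lower numbers for stronger inhibition), compound 3 gives 5700 nM, the second highest of the three numbers. Its nearest neighbour is compound 2, and the step of a 1.1-fold lower number from compound 2 to compound 3 (0.05 log units; within the scatter) lies within the scatter, so these two cannot be told apart. Compound 1 sits further off: the step of a 2.0-fold higher number from compound 1 to compound 3 (0.31 log units; beyond the scatter) is modest but beyond the scatter, and the step of a 2.3-fold higher number from compound 1 to compound 2 (0.35 log units; beyond the scatter) points the same way.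

Compound 4 `CN1CCN(c2ccc(Nc3nc(-c4cccc(NC(=O)c5ccc(F)c(Cl)c5)c4)sc3C(N)=O)cc2)CC1` has not yet been measured. It differs from compound 3 in one place: 3-chloro-4-fluorophenyl in place of 4-chlorophenyl on a carbonyl carbon. Within the data shown here, in plain words, the chlorine of compound 3 stays and a fluorine is added to the same ring, though at a position different from the one it occupies in compound 1.

The measured steps only tell how a single fluoro, chloro or hydrogen behaves on that ring. A fluoro alone gave the lowest number, while the chloro alone matched hydrogen. Among the measured compounds shown here, no step shows what fluoro and chloro together do. On this thin footing, compound 4 is expected to stay close to compound 3, with at most a small shift toward a lower number, which is the estimated step of a 1.3-fold lower number from compound 3 to compound 4 (0.10 log units; within the scatter). The estimate for compound 4 in this assay is therefore 4500 nM, with a range from 1800 nM to 11000 nM.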

Compound 4, half-maximal inhibitory concentration: 6230 nM
Compound 4: middle estimate off by 1.4-fold (0.14 log units), on the low side; low and high end bracket the measured number.
By their numbers in this assay, from the lowest: compound 1; then compounds 3, 4 and 2 (each within the scatter of the next).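

In this assay, putting a chlorine on the fluorinated ring of compound 1 gives a modest loss (a 2.2-fold higher number from compound 1 to compound 4 (0.34 log units; beyond the scatter)), so the lower number of compound 1 does not survive once both halogens share the ring. The 3-chloro-4-fluorophenyl group cannot be told apart from 4-chlorophenyl (a 1.1-fold higher number from compound 3 to compound 4 (0.04 log units; within the scatter)) or from plain phenyl (a 1.0-fold lower number from compound 2 to compound 4 (0.01 log units; within the scatter)), which leaves compound 1 as the only one of the four that stands apart at this position. Chloro in place of hydrogen shows no measurable effect on the ring without fluorine and a modest loss on the ring with it, yet these two steps cannot be said to differ: (the same change on two cores in this assay, a 1.1-fold lower number (0.05 log units; within the scatter) from compound 2 to compound 3 and a 2.2-fold higher number (0.34 log units; beyond the scatter) from compound 1 to compound 4, 2.5-fold (0.39 log units) apart, within the scatter of two such steps).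

Only hydrogen and halogens on this ring are shown, so whether a methoxy group, an amine or a carboxylic acid here would move the number stays open. Also open, as far as these compounds go, is whether 3,4-difluorophenyl would keep the number of compound 1 or fall in with compounds 2, 3 and 4.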